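This account rests on a few compounds, and the source may have more. Where it says the series, first, only, none or still open, it means among the compounds named here.

Of the compounds shown here, three have been measured in a functional assay on MCF7 cells (Homo sapiens) for inhibition, read by sulforhodamine B assay, with a stated time of 48 h; a higher number here means a weaker inhibitor of growth, a lower number a stronger inhibitor of growth.

Compound 1 `COc1ccc(/C=N/NC(=S)NC(C)(C)[C@H]2CC=C(C)CC2)cc1` gives 31200 nM.
Compound 2 `CC1=CC[C@H](C(C)(C)NC(=S)N/N=C/c2ccc(F)cc2)CC1` gives > 100000 nM, which is a limit of the assay rather than a number.
Compound 3 `CC1=CC[C@H](C(C)(C)NC(=S)N/N=C/c2ccc(Cl)cc2)CC1` gives 18300 nM.

Compound 3 stands lowest of the two numbers shown, with compound 1 nearest to it; the step of a 1.7-fold lower number from compound 1 to compound 3 (0.23 log units; within the scatter) lies within the scatter. The other measured steps are an at least 3.2-fold higher number from compound 1 to compound 2 (0.50 log units; beyond the scatter) and an at least 5.4-fold lower number from compound 2 to compound 3 (0.73 log units; beyond the scatter), both of which run through the limit of > 100000 nM in this assay, at which 1 of the 3 values shown sits, and so give only a bound rather than a size. Compound 4 `CC1=CC[C@H](C(C)(C)NC(=S)N/N=C/c2ccc[nH]2)CC1` differs from compound 3 in one place: 1H-pyrrol-2-yl in place of 4-chlorophenyl on a carbon with a double bond to nitrogen. For the measured compounds named here, none of the measured steps exchanges the ring itself; all three swap a single substituent on the same aromatic ring, so they bear on this change only loosely, showing that the number can move by a modest amount or more when that part of the molecule is altered. Replacing the whole chloro-bearing ring is therefore expected to move this assay upward, probably beyond the scatter, with a fair chance of reaching the limit. Compound 4 is estimated at 45000 nM, in the range 15000 nM to 130000 nM. The step of a 2.5-fold higher number from compound 3 to compound 4 (0.39 log units; beyond the scatter) is the shift expected from compound 3.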

Compound 4, concentration for 50% growth inhibition: 3900 nM
Beside the measured number, compound 4's estimate is 12-fold (1.06 log units) above it; measured number below the stated range.
By their numbers in this assay, from the lowest: compound 4; then compounds 3 and 1 (each within the scatter of the next). At a limit, above all of these: compound 2.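

In this assay, for the compounds shown here, the earlier compounds showed only exchanges of a single substituent on the aromatic ring, whereas replacing the whole ring on the carbon with a double bond to nitrogen by 1H-pyrrol-2-yl lowers the number: a 4.7-fold lower number from compound 3 to compound 4 (0.67 log units; beyond the scatter) and an 8.0-fold lower number from compound 1 to compound 4 (0.90 log units; beyond the scatter). Compound 2 stands at a limit, not at a number: the limit of > 100000 nM in this assay, at which 1 of the 4 values shown sits. Read only as a bound, the same exchange from 4-fluorophenyl gives an at least 25-fold lower number from compound 2 to compound 4 (1.40 log units; beyond the scatter), so in all three pairs shown this position accepts the loss of the substituted six-membered ring, and the number falls.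

The compounds shown leave open whether the smaller ring or its hydrogen-bond donor goes with this step. A furan-2-yl or a 1-methylpyrrol-2-yl group on the same carbon would bear on that question.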